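A few compounds are considered here, and "the series" means these few. Any claim that something is new, unique, unknown or untested is made for them only; others in the source may bear on it.

Measured in a functional assay on HL-60 cells (Homo sapiens) for cytotoxicity, read by WST assay, with a stated time of 48 h; on this read-out higher numbers stand for an effect only at larger amounts of compound and lower numbers for an effect already at smaller amounts:
Compound 1 `Cc1ccccc1C[C@H]1C(=O)OC[C@@H]1Cc1ccccc1`: 57000 nM
Compound 2 `O=C1OC[C@H](Cc2ccccc2)[C@H]1Cc1ccccc1F`: 72000 nM
Compound 3 `O=C1OC[C@H](Cc2ccccc2)[C@H]1Cc1ccccc1Cl`: 37000 nM

Compound 3, at 37000 nM, cannot be separated from the other two compounds, since its steps to both lie within the scatter, the spread that repeat measurements alone can produce.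

Compound 4 `O=C1OC[C@H](Cc2ccccc2)[C@H]1Cc1cccc(O)c1` has not been measured. It carries 3-hydroxyphenyl in place of 2-chlorophenyl on a saturated chain carbon bound to a saturated ring carbon.

Within the data shown here, three measured steps bear on this change: a 1.3-fold higher number from compound 1 to compound 2 (0.10 log units; within the scatter), a 1.5-fold lower number from compound 1 to compound 3 (0.19 log units; within the scatter) and a 1.9-fold lower number from compound 2 to compound 3 (0.29 log units; within the scatter). Each swaps one group on the same aromatic ring, and all three stay within the scatter. None of them tests a hydroxy group, however, so the data offer only indirect guidance for this swap. Three small steps give no reason to expect a real shift in this assay, in either direction, although an untested group calls for a wide range.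

The estimated change is a 1.1-fold higher number from compound 3 to compound 4 (0.03 log units; within the scatter), which would be no step beyond the scatter. For compound 4 the expected value is 40000 nM, with an estimated range from 13000 nM to 100000 nM.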

Compound 4, half-maximal effective concentration: > 100000 nM
Compound 4 ended at the assay's limit; the forecaster's own chance of this, stated with the estimate: 10%; middle value at least 2.5-fold (0.39 log units) away from the limit.
By their numbers in this assay, from the lowest: compounds 3, 1 and 2 (each within the scatter of the next). At a limit, above all of these: compound 4.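

In this assay compound 4 gives > 100000 nM, which is a limit of the assay and not a number. Even so, placing 3-hydroxyphenyl in place of 2-chlorophenyl on a saturated chain carbon bound to a saturated ring carbon gives the only step beyond the scatter in this set, an at least 2.7-fold higher number from compound 3 to compound 4 (0.43 log units; beyond the scatter), so this position can register a change in the assay, which the swaps among the methyl, fluoro and chloro compounds could not show. The other two steps, an at least 1.3-fold higher number from compound 2 to compound 4 (0.14 log units; that floor lies within the scatter) and an at least 1.7-fold higher number from compound 1 to compound 4 (0.24 log units; that floor lies within the scatter), do not separate compound 4 from compound 2 or compound 1, and the true size of all three steps stays hidden behind the limit: the limit of > 100000 nM in this assay, at which 1 of the 4 values shown sits.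

From the compounds shown here alone, what 2-hydroxyphenyl or 3-chlorophenyl would give remains open, so the effect of the hydroxy group cannot be told apart from the effect of where a group sits on the phenyl ring. Also open, going by these compounds, is how related groups such as 3-methoxyphenyl or 3-aminophenyl would read at this position.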